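This account rests on a few compounds, and the source may have more. Where it says the series, first, only, none or still open, it means among the compounds named here.

Among the measured compounds shown here, in a functional assay on A549 cells (Homo sapiens) for antiproliferative activity, read by MTT assay, with a stated time of 48 h (a higher number here means a weaker inhibitor, a lower number a stronger inhibitor), compound 2 (`O=C(/C=C/c1ccccc1)Nc1nnc(-c2ccccc2)s1`) gives 1.75 ug/mL and holds the lower of the two numbers so far, a gap beyond the scatter from compound 1 (`O=C(/C=C/c1ccc(C(F)(F)F)cc1)Nc1nnc(-c2ccc(Br)cc2)s1`), which gives 4.68 ug/mL in the same read-out. Compound 3 (`O=C(/C=C/c1ccc(F)cc1)Nc1nnc(-c2ccccc2)s1`) has fluoro in place of hydrogen on an aromatic carbon, para to a large group, which turns phenyl to 4-fluorophenyl (fluoro in place of hydrogen on an aromatic carbon). For the measured compounds named here, no measured pair shows this change, so the expected step of a 1.1-fold higher number from compound 2 to compound 3 (0.06 log units; within the scatter) in this assay is a small rise that stays within the scatter. Compound 3 is estimated at 2 ug/mL (expected range 1 ug/mL to 4 ug/mL).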

Compound 3, half-maximal inhibitory concentration: 1.82 ug/mL
Compound 3: the middle estimate sits 1.1-fold (0.04 log units) above what was measured; low and high end bracket the measured number.
By their numbers in this assay, from the lowest: compounds 2 and 3 (each within the scatter of the next); then compound 1.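

Among the compounds shown here, this is the first comparison that differs in one place: in this assay the step from phenyl to 4-fluorophenyl, a 1.0-fold higher number from compound 2 to compound 3 (0.02 log units; within the scatter), lies within the scatter. At this aromatic carbon, para to a large group, fluoro in place of hydrogen therefore leaves the read-out indistinguishable from hydrogen. Nothing available explains this result. Still open, going by these compounds, is whether a bulkier or ionisable group on this carbon, such as an amine, a methoxy group or a carboxylic acid, would give a number as close to that of compound 2.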